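The source may report more compounds than this note shows. Statements on the series, on what has been measured and on what is new or still open speak of the compounds shown alone.

Measured so far in a functional assay on MDCK cells (Canis lupus familiaris) for inhibition; a higher number here means that more compound is tolerated, a lower number that less compound is tolerated:
- compound 1 `Cn1c(CC2(C)CO2)cc(=O)n(C)c1=O`: 4000 nM
- compound 2 `Cn1c(CC2(c3ccccc3)CO2)cc(=O)n(C)c1=O`: 3700 nM

Compound 2 stands at 3700 nM, and compound 1 at 4000 nM. These two numbers lie within the scatter of each other, so this assay does not separate the pair.

The next compound is compound 3 `Cn1c(CC2(C(C)(C)C)CO2)cc(=O)n(C)c1=O`, which keeps the shared core and changes only the group on the epoxide-free description's carbon named here: tert-butyl in place of phenyl on a saturated ring carbon. In words, it has tert-butyl in place of phenyl on a saturated ring carbon, next to the ring oxygen.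

Among the compounds with values here, only one measured step bears on this change, a 1.1-fold lower number from compound 1 to compound 2 (0.03 log units; within the scatter). It replaced methyl with phenyl at the same saturated ring carbon and stayed within the scatter. Within the data shown here, that single step is the whole evidence, and no compound with tert-butyl has yet been measured. A step beyond the scatter is therefore not expected in this assay, and no direction can be favoured. The expected change is a 1.0-fold higher number from compound 2 to compound 3 (0.01 log units; within the scatter). For compound 3 the estimated value is 3800 nM, with an expected range from 1800 nM to 8000 nM.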

Compound 3, half-maximal cytotoxic concentration: 7900 nM
The estimate for compound 3 lay 2.1-fold (0.32 log units) below the measured number; the range from low to high includes it.
By their numbers in this assay, from the lowest: compounds 2, 1 and 3 (each within the scatter of the next, the first and the last beyond it).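

At this saturated ring carbon, next to the ring oxygen, the methyl-to-phenyl change had given no step beyond the scatter, whereas in this assay tert-butyl in place of phenyl gives the first such step, a 2.1-fold higher number from compound 2 to compound 3 (0.33 log units; beyond the scatter), so the group at this position can shift the tolerated concentration, if only modestly. The same tert-butyl in place of methyl gives a 2.0-fold higher number from compound 1 to compound 3 (0.30 log units; within the scatter), which stays within the scatter, so only compound 2 and compound 3 are separated, and compound 1 cannot be told from either of them. Nothing in the data accounts for this modest separation.

The compounds shown leave open whether an amine, a carboxylic acid or a longer alkyl chain on this carbon would move the number further than tert-butyl does, or in the opposite direction from it. They also leave open how much the three-membered ring with its oxygen contributes, since all three compounds keep it and differ only in the group on its saturated ring carbon.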